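Aryl Hydroxamic Acids in Huh-7 Cells: Predicting Compound 4

The source may hold more compounds than are shown below. What is called first, only, known or untested is meant among the compounds shown, and "the series" means these compounds.

Three hydroxamic acids have been tested in an ADME assay on Huh-7 cells (Homo sapiens) for cytotoxicity, read by MTT assay, with a stated time of 3 days; on this read-out lower numbers stand for higher toxicity in this test and higher numbers for lower toxicity in this test. Compound 1 `O=C(/C=C/c1ccc(OCCc2ccccc2)cc1)NO` gives 16000 nM, the lowest of the three numbers. Compound 2 `O=C(/C=C/c1ccccc1OCCOc1ccccc1)NO` gives 45000 nM, and compound 3 `O=C(/C=C/c1ccccc1OCCc1ccccc1)NO` gives 83000 nM. Compound 1 and compound 3 contain the same atoms joined differently; the difference between the two cores is not broken down here. Compound 3 and compound 2 differ in one place: phenoxy in place of phenyl on a saturated chain carbon, two bonds along the chain from an oxygen on an aromatic ring. That change gave a 1.8-fold lower number from compound 3 to compound 2 (0.27 log units; within the scatter), so the two values cannot be ordered.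

Compound 4 `O=C(/C=C/c1ccc(OCCOc2ccccc2)cc1)NO` has not yet been measured. It differs from compound 1 by the same change, made at the same kind of place: phenoxy in place of phenyl on a saturated chain carbon, two bonds along the chain from an oxygen on an aromatic ring. The expected step is a 1.3-fold lower number from compound 1 to compound 4 (0.12 log units; within the scatter), because the same change earlier gave a 1.8-fold lower number from compound 3 to compound 2 (0.27 log units; within the scatter). In this assay compound 4 is therefore estimated at 12000 nM, with a likely range from 5000 nM to 30000 nM. This expectation rests on a single earlier example of the change, made on a differently joined core, so the range is kept wide.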

Compound 4, half-maximal cytotoxic concentration: 5700 nM
Compound 4: middle estimate off by 2.1-fold (0.32 log units), on the high side; the range from low to high includes it.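

Putting phenoxy in place of phenyl gave a 2.8-fold lower number from compound 1 to compound 4 (0.45 log units; beyond the scatter) in this assay, and on this read-out a lower number stands for higher toxicity in this test. Set beside the earlier case, the two steps cannot be told apart, so as far as these numbers can say, the change behaved alike on both cores: the same change on two cores in this assay, a 1.8-fold lower number (0.27 log units; within the scatter) from compound 3 to compound 2 and a 2.8-fold lower number (0.45 log units; beyond the scatter) from compound 1 to compound 4, 1.5-fold (0.18 log units) apart, within the scatter of two such steps. Within the data shown here, this does not show a fixed size for the step: there are only two pairs, the step on the other core lies within the scatter on its own, and nothing here tells why the numbers move.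

The compounds shown leave open how this assay would read with an amine or a carboxylic acid in place of phenoxy. They also leave open whether the same change would give a step of similar size with a longer chain, or on a third core.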